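The source may hold more compounds than are shown below. What is called first, only, known or untested is meant among the compounds shown, and "the series" means these compounds.

Of the compounds shown here, three have been measured so far in an ADME assay for permeability, using PAMPA, with a stated time of 12 h, at pH 7.4, tested at 10 uM (on this read-out higher numbers stand for higher permeability and lower numbers for lower permeability), and their numbers sit close together. Compound 1 `CCOS(=O)(=O)/C=C/c1ccc(O[C@H]2CNC[C@H]2Oc2ccc(/C=C/S(=O)(=O)OCC)cc2)cc1` gives 0.87 10^-6 cm/s, compound 2 `CCCCCCCCCCc1ccc(NC(=O)C(=O)N2C[C@H](Oc3ccc(CCS(=O)(=O)OCC)cc3)[C@H](Oc3ccc(/C=C/S(=O)(=O)OCC)cc3)C2)cc1` gives 1.82 10^-6 cm/s and compound 3 `CCOS(=O)(=O)/C=C/c1ccc(O[C@@H]2CN(C(=O)C(=O)Nc3ccccc3)C[C@@H]2Oc2ccc(CCS(=O)(=O)OCC)cc2)cc1` gives 1.09 10^-6 cm/s on this read-out. Compound 2 stands within the scatter of compound 3, while compound 1 lies lower than compound 2 by a margin just beyond the scatter. Compound 4 `CCCCCCCCCCc1ccc(NC(=O)C(=O)N2C[C@@H](Oc3ccc(/C=C/S(=O)(=O)OCC)cc3)[C@H](Oc3ccc(CCS(=O)(=O)OCC)cc3)C2)cc1` has not yet been measured. Set against compound 2, its structure shows the two compounds have the same atoms and bonds and differ only in configuration as drawn: 1 of 3 stereo elements differ; a stereocentre at a saturated ring carbon is drawn S in compound 2 and R in compound 4 and no other change: the two compounds have the same atoms and bonds, and a stereocentre at a saturated ring carbon is drawn S in compound 2 and R in compound 4. Going by the values given here, no measured pair differs in configuration alone, so the data give no direct size for such a change. Among the compounds with values here, the only measured step, a 1.7-fold lower number from compound 2 to compound 3 (0.22 log units; within the scatter) with hydrogen in place of decyl on an aromatic carbon, stays within the scatter although it is a far larger structural change. In this assay the expected step is therefore a 1.1-fold lower number from compound 2 to compound 4 (0.03 log units; within the scatter) with no direction that the data can support, and none beyond the scatter is expected. For compound 4 the estimate is 1.7 10^-6 cm/s with an expected range from 0.9 10^-6 cm/s to 3.2 10^-6 cm/s once it is measured.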

Compound 4, apparent permeability: 1.93 10^-6 cm/s
Compound 4: middle estimate off by 1.1-fold (0.06 log units), on the low side; measured number inside the range.
By their numbers in this assay, from the lowest: compounds 1, 3, 2 and 4 (each within the scatter of the next, the first and the last beyond it).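

In this assay the study now has a direct reading of a change of configuration alone, and it is a 1.1-fold higher number from compound 2 to compound 4 (0.03 log units; within the scatter). With the decyl group and everything else held in place, the read-out does not tell apart the two drawings of this stereocentre at a saturated ring carbon, S in compound 2 and R in compound 4. The step can be read on this one stereocentre without any other structural change entering the comparison: the fact that compounds 2 and 4 differ only in the configuration as drawn.

The compounds shown leave open whether the same stereocentre change would read alike without the decyl group, and whether a change at the other stereo elements would do the same, as no pair here speaks to either. They also leave open how this assay would respond to a carboxylic acid or an amine in place of decyl on an aromatic carbon, as the only replacement at that place shown here is hydrogen, with a 1.7-fold lower number from compound 2 to compound 3 (0.22 log units; within the scatter).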